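The source may report more compounds than this note shows. Statements on the series, on what has been measured and on what is new or still open speak of the compounds shown alone.

Compound 1 `CCOc1cccc2c1C(=O)N(Cc1cc(Br)ccc1NC(=O)c1ccccn1)C2=O`: 720 nM
Compound 2 `O=C(Nc1ccc(Cl)cc1CN1C(=O)c2ccccc2C1=O)C1CCCCC1`: 1500 nM
Compound 3 `Cc1ccc2c(c1C)C(=O)N(Cc1cc(Cl)ccc1NC(=O)c1ccccn1)C2=O`: 2200 nM

All three were measured in an assay on CHO cells for positive allosteric modulation of metabotropic glutamate receptor 5 (Homo sapiens), read by FLIPR; on this read-out higher numbers stand for an effect only at larger amounts of compound and lower numbers for an effect already at smaller amounts. Among them compound 2 holds the second highest of the three numbers. Its nearest neighbour is compound 3, whose number lies within the scatter of that of compound 2, while compound 1 lies furthest, with a lower number beyond the scatter. Compound 1 and compound 3 each differ from compound 2 in more than one place, so no single step can be read from either of them.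

Compound 4 `O=C(Nc1ccc(Cl)cc1CN1C(=O)c2ccccc2C1=O)c1cccnc1` has not yet been measured. Among the compounds with values here, it differs from compound 2 in one place: pyridin-3-yl in place of cyclohexyl on a carbonyl carbon No measured pair shows this change, and the expectation therefore rests only on the spread of the three numbers. The step from compound 2 to compound 4 in this assay is expected to be small, in no particular direction, estimated as a 1.3-fold lower number from compound 2 to compound 4 (0.10 log units; within the scatter). Compound 4 is accordingly estimated at 1200 nM, within a range from 400 nM to 3500 nM.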

Compound 4, half-maximal effective concentration: 35000 nM
Compound 4: middle estimate off by 29-fold (1.46 log units), on the low side, and the stated range ends below it.
By their numbers in this assay, from the lowest: compound 1; then compounds 2 and 3 (each within the scatter of the next); then compound 4.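

In this assay, within the data shown here, the group on this carbonyl carbon proves far from interchangeable: pyridin-3-yl in place of cyclohexyl brings a 23-fold higher number from compound 2 to compound 4 (1.37 log units; beyond the scatter), a large step that the earlier compounds, with no single-place pair among them, could not reveal. The two groups have the same count of heavy atoms, each in one six-membered ring, so that count does not separate them; they differ in an aromatic ring with one nitrogen and one hydrogen-bond acceptor against a non-aromatic ring of carbon only. No measurement here bears on the reason for the size of this step.

From the compounds shown here alone, it remains open whether the step follows the aromatic ring or its nitrogen, which phenyl on the same carbonyl carbon could separate. Pyridin-2-yl and pyridin-4-yl in this place would show whether the position of the nitrogen matters.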